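The source may hold more compounds than are shown below. What is called first, only, known or untested is meant among the compounds shown, and "the series" means these compounds.

Compound 1 `O=C(N/N=C/c1cccc(F)c1)c1cnccn1` gives 46%
Compound 2 `CCOc1ccc(/C=N/NC(=O)c2cnccn2)cc1` gives 98%
Compound 3 `O=C(N/N=C/c1ccccc1O)c1cnccn1` gives 0.3%

In an ADME assay on J774 cells (Mus musculus) for cytotoxicity, read by MTT assay, with a stated time of 48 h, tested at 100 ug/mL (a higher number here means a weaker effect of the compound at the concentration tested, a lower number a stronger effect), compound 1 holds the second highest of the three numbers. Compound 2 stands higher, beyond the scatter, and compound 3 stands lower, again beyond the scatter. Within the data shown here, no step between two measured compounds that differ in a single place is known here.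

Compound 4 `O=C(N/N=C/c1cccc(O)c1)c1cnccn1` differs from compound 1 by hydroxy in place of fluoro on an aromatic carbon. Compound 3 also carries a hydroxy, and since in this assay compound 3 gives 0.3%, a move downward beyond the scatter is expected, though its size is uncertain. The expected step from compound 1 to compound 4 is a number 21 percentage points lower from compound 1 to compound 4 (beyond the scatter). Compound 4 is therefore estimated at 25%, within 2% to 75%.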

Compound 4, a percentage reported as activity, at one concentration (the size of the read-out at that concentration, not a potency): 100%
Compound 4: the middle estimate sits 75 percentage points below what was measured; measured number outside the range, above it.
By their numbers in this assay, from the lowest: compound 3; then compound 1; then compounds 2 and 4 (each within the scatter of the next).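

On this aromatic carbon, meta to a large group, hydroxy in place of fluoro weakens the effect in this assay, with a number 54 percentage points higher from compound 1 to compound 4 (beyond the scatter). A hydroxy on the ring therefore does not by itself bring a low number: compound 3, which carries its hydroxy at another place, gives 0.3%, while compound 4 gives 100%. Nothing available explains this step.

From the compounds shown here alone, whether an amine or a methoxy at this same place would read like the hydroxy or like the fluoro remains open. So does whether the hydroxy would give a similar step on a different core.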